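A few compounds are considered here, and "the series" means these few. Any claim that something is new, unique, unknown or untested is made for them only; others in the source may bear on it.

In a functional assay on QGY-7703 cells (Homo sapiens) for cytotoxicity, read by MTT assay, with a stated time of 24 h (on this read-out lower numbers stand for stronger inhibition and higher numbers for weaker inhibition), compound 1 (`N#Cc1ccc(/C=C2\CN(S(=O)(=O)c3ccc(F)cc3)C/C(=C\c3ccc(C#N)cc3)C2=O)cc1`) gives 11300 nM as the highest of the three numbers in hand. Compound 4 (`N#Cc1ccc(/C=C2\CN(S(=O)(=O)c3ccc(F)cc3)C/C(=C\c3ccccc3F)C2=O)cc1`) is still unmeasured and differs from compound 1 by 2-fluorophenyl in place of 4-cyanophenyl on a double-bonded chain carbon bound to a double-bonded ring carbon in one place, a double-bonded chain carbon bound to a double-bonded ring carbon, where 2-fluorophenyl stands in place of 4-cyanophenyl. Among the compounds with values here, the one measured single-place step (a 3.4-fold lower number from compound 1 to compound 3 (0.53 log units; beyond the scatter)) is modest, but it comes from acetamido in place of fluoro on an aromatic carbon, a different change, so it says little here. Closer to the question, compound 2 (`CC(=O)Nc1ccc(S(=O)(=O)N2C/C(=C\c3ccccc3F)C(=O)/C(=C/c3ccccc3F)C2)cc1`) with 2-fluorophenyl on both such chain carbons gives 5500 nM and compound 3 (`CC(=O)Nc1ccc(S(=O)(=O)N2C/C(=C\c3ccc(C#N)cc3)C(=O)/C(=C/c3ccc(C#N)cc3)C2)cc1`) with 4-cyanophenyl there gives 3320 nM as two values within the usual scatter of each other. That pair carries acetamido rather than the fluoro of compound 1, so the read-across is indirect. No step beyond the scatter is therefore expected in this assay for this change. The estimated step (a 1.3-fold lower number from compound 1 to compound 4 (0.10 log units; within the scatter)) stays small. For compound 4 the expected value is 9000 nM within an estimated range of 4500 nM to 18000 nM on repeat measurement.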

Compound 4, half-maximal inhibitory concentration: 20100 nM
Compound 4: middle estimate off by 2.2-fold (0.35 log units), on the low side; the measured number lies above the stated range.
By their numbers in this assay, from the lowest: compounds 3 and 2 (each within the scatter of the next); then compounds 1 and 4 (each within the scatter of the next).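

In this assay, 2-fluorophenyl in place of 4-cyanophenyl on a double-bonded chain carbon bound to a double-bonded ring carbon gives a 1.8-fold higher number from compound 1 to compound 4 (0.25 log units; within the scatter), so this single change has a direct reading that stays within the scatter. The earlier reading of this position rested only on acetamido-bearing compounds with the same group on both such chain carbons, whereas this pair keeps the fluoro on the aromatic carbon and changes one place. No supporting measurement is available to explain the size of this step.

The compounds shown leave open whether the same change gives a step of similar size when acetamido replaces the fluoro. They also leave open how a carboxylic acid or an amine on the aryl ring at this chain carbon would read.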